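This account rests on a few compounds, and the source may have more. Where it says the series, first, only, none or still open, it means among the compounds named here.

Among the measured compounds shown here, in a functional assay on MCF7 cells (Homo sapiens) for cytotoxicity, read by sulforhodamine B assay, with a stated time of 24 h (a higher number here means a weaker inhibitor, a lower number a stronger inhibitor), compound 1 (`O=C1Nc2ccc(S(=O)(=O)N3CCOCC3)cc2/C1=N/c1cccc(C(F)(F)F)c1`) gives 41100 nM and stands at the high end of the numbers measured so far. Compound 2 (`COc1ccc(-c2c(C#N)c(N)n(/N=C3\C(=O)Nc4ccc(S(=O)(=O)N5CCOCC5)cc43)c(=O)c2C#N)cc1`) gives 33400 nM as well, a value within the usual scatter of that of compound 1. Compound 3 (`O=C1Nc2ccc(S(=O)(=O)N3CCOCC3)cc2/C1=N/c1ccc(/N=C2\C(=O)Nc3ccc(S(=O)(=O)N4CCOCC4)cc32)cc1`) gives 10900 nM as its value, a lower number than that of compound 1 and beyond the scatter.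

Compound 4 (`O=C1Nc2ccc(S(=O)(=O)N3CCOCC3)cc2/C1=N/c1ccc(Cl)cc1`) has not yet been measured. It carries 4-chlorophenyl in place of 3-(trifluoromethyl)phenyl on a double-bonded nitrogen. For the measured compounds named here, no two measured compounds differ in one place only, so the data offer no direct precedent for this step. The expectation rests on compound 1 at 41100 nM and compound 2 at 33400 nM as the closest guide, since these two carry quite different groups on that nitrogen and still lie within the scatter of each other. No change beyond the scatter is therefore expected in either direction, and the expected step of a 1.2-fold lower number from compound 1 to compound 4 (0.07 log units; within the scatter) is a small one. For compound 4 the estimated value is 35000 nM with an expected range from 15000 nM to 80000 nM in this assay.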

Compound 4, half-maximal inhibitory concentration: 44300 nM
Compound 4: middle estimate off by 1.3-fold (0.10 log units), on the low side; low and high end bracket the measured number.
By their numbers in this assay, from the lowest: compound 3; then compounds 2, 1 and 4 (each within the scatter of the next).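

In this assay, among the compounds shown here, replacing 3-(trifluoromethyl)phenyl with 4-chlorophenyl on a double-bonded nitrogen gives a 1.1-fold higher number from compound 1 to compound 4 (0.03 log units; within the scatter), the first direct reading of a single change at this place. Both groups contain one six-membered aromatic ring of carbon only and carry no net charge, yet they differ in substituent, in its printed ring number and in heavy-atom count, and this combined exchange still leaves the step within the scatter. No measurement of any other kind bears on this result, so the data give no explanation for it.

The compounds shown leave open whether an amine or a carboxylic acid on the phenyl ring, or a longer alkyl chain in place of that ring, would produce a step beyond the scatter at this position. For the compounds shown here, they also leave open how each part of this exchange acts alone, since the single step changes the substituent and its printed ring number together, and whether the same exchange would read alike on a core other than that of compound 1.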